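A few compounds are considered here, and "the series" means these few. Any claim that something is new, unique, unknown or untested is made for them only; others in the source may bear on it.

Of the compounds shown here, two built on one shared core have been tested in an assay on isolated protein for inhibition of Apoptosis regulator Bcl-2 (Homo sapiens), read by fluorescence polarization, with stated times of 5 min and 10 min; on this read-out higher numbers stand for weaker inhibition and lower numbers for stronger inhibition. Compound 1 `CC(C)=CCCC1=CC[C@@H](C(=O)NCCC(=O)O)[C@H](c2ccccc2)C1` carries a (2-carboxyethyl)amino group on its carbonyl carbon. In this assay compound 1 gives > 23000 nM, which is a limit of the assay rather than a number. Compound 2 `CON(C)C(=O)[C@@H]1CC=C(CCC=C(C)C)C[C@H]1c1ccccc1` carries a methoxy(methyl)amino group on that carbonyl carbon instead. In this assay compound 2 gives > 23000 nM, again a limit rather than a number. The step that the two limits leave unreadable from compound 1 to compound 2 is therefore unreadable, since the limit of > 23000 nM in this assay, at which 2 of the 2 values shown sit, describes where both values sit. Compound 3 `CC(C)=CCCC1=CC[C@@H](C(=O)N(C)O)[C@H](c2ccccc2)C1` differs from compound 2 by hydrogen in place of methyl on an oxygen. Going by the values given here, no measured step bears directly on this change, and the one measured step has no readable size. Compound 3 is therefore expected to sit near the same limit, with the step that the limit leaves unreadable from compound 2 to compound 3 estimated as small. Compound 3 is expected to show about 30000 nM, within 8000 nM to 120000 nM.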

Compound 3, inhibition constant: 2300 nM
Compound 3: the middle estimate sits 13-fold (1.12 log units) above what was measured, outside the stated range (below it).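

At this place, on an oxygen bound to an amide-type nitrogen, hydrogen in place of methyl is the first change shown to give a readable number, with an at least 10-fold lower number from compound 2 to compound 3 (1.00 log units; beyond the scatter) in this assay. Compared with the (2-carboxyethyl)amino group on the carbonyl carbon, the hydroxy(methyl)amino group also gives an at least 10-fold lower number from compound 1 to compound 3 (1.00 log units; beyond the scatter). Only compound 3 has a value that is not a limit, so the full size of both steps remains unknown: the limit of > 23000 nM in this assay, at which 2 of the 3 values shown sit.

The compounds shown leave open whether the hydroxy group alone is enough or whether the methyl on the nitrogen also contributes. A hydroxyamino group without that methyl, or a carboxylic acid in place of the whole amide, would show how much the result depends on this exact group.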